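A Longer Chain on the Urea Nitrogen of Compound 2

This account rests on a few compounds, and the source may have more. Where it says the series, first, only, none or still open, it means among the compounds named here.

Of the compounds shown here, three sharing one core have been measured in a functional assay on U-87MG ATCC cells for antiproliferative activity against U-87 MG (Homo sapiens), read by MTT assay, with a stated time of 72 h; on this read-out higher numbers stand for weaker inhibition and lower numbers for stronger inhibition. Compound 1 `COc1ncc(-c2ccc3nc(NC(=O)NC4CC4)sc3c2)cc1NS(=O)(=O)c1ccc(F)cc1` gives 520 nM. Compound 2 `CNC(=O)Nc1nc2ccc(-c3cnc(OC)c(NS(=O)(=O)c4ccc(F)cc4)c3)cc2s1` gives 1230 nM, and compound 3 `CCN(CC)CCNC(=O)Nc1nc2ccc(-c3cnc(Cl)c(NS(=O)(=O)c4ccc(F)cc4)c3)cc2s1` gives 1390 nM. Among these three numbers compound 2 stands second highest: its nearest neighbour is compound 3, within the scatter, while compound 1 lies furthest away, beyond the scatter. Within the data shown here, the only single-place step recorded is a 2.4-fold higher number from compound 1 to compound 2 (0.37 log units; beyond the scatter), a modest step.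

Compound 4 `COc1ncc(-c2ccc3nc(NC(=O)NCCN4CCN(C)CC4)sc3c2)cc1NS(=O)(=O)c1ccc(F)cc1` has not yet been measured. It differs from compound 2 by (4-methylpiperazin-1-yl)methyl in place of hydrogen on a saturated chain carbon bound to an amide-type nitrogen. Among the measured compounds shown here, no recorded single-place step matches this change. The step from compound 1 to compound 2 concerns a different exchange at an amide-type nitrogen and is modest in size. Compound 3, which also bears a longer chain on an amide-type nitrogen, although it differs from compound 2 elsewhere as well, gives a number within the scatter of compound 2. On this basis little movement beyond the scatter is expected in this assay, and the expected step is a 1.2-fold lower number from compound 2 to compound 4 (0.09 log units; within the scatter). Compound 4 is therefore estimated at 1000 nM, within a range from 350 nM to 2800 nM.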

Compound 4, half-maximal inhibitory concentration: 440 nM
Estimate against measurement, compound 4: 2.3-fold (0.36 log units) above; measured number inside the range.
By their numbers in this assay, from the lowest: compounds 4 and 1 (each within the scatter of the next); then compounds 2 and 3 (each within the scatter of the next).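

In this assay, replacing methyl with 2-(4-methylpiperazin-1-yl)ethyl on the amide-type nitrogen gives a 2.8-fold lower number from compound 2 to compound 4 (0.45 log units; beyond the scatter) and so shows that this nitrogen can carry a much larger group, one that includes a six-membered non-aromatic ring with 2 hetero atoms, with stronger inhibition rather than a loss. Set against the small cyclopropyl group of compound 1, the same chain gives a 1.2-fold lower number from compound 1 to compound 4 (0.07 log units; within the scatter), which means that two very different groups at this nitrogen cannot be told apart here, while methyl in compound 2 gives the weaker inhibition of the three compounds that differ only at this place. Nothing available explains why methyl behaves differently from the other two groups.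

On these data alone, it remains open whether the piperazine ring matters at all, or whether a plain butyl chain or a 2-(morpholin-4-yl)ethyl chain on the same nitrogen would give a similar number. Compound 3 cannot settle this, since its 2-(diethylamino)ethyl chain comes with a second difference elsewhere in the molecule.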